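The compounds below may be only part of what the source reports. "The series", "measured", "known", "first", "only" and "open" are said of these compounds alone.

Measured so far:

- compound 1, `COc1cc2ccc(=O)oc2cc1OCCOc1no[n+]([O-])c1S(=O)(=O)c1ccccc1`: 3610 nM in a functional assay on HepG2 cells (Homo sapiens) for inhibition, read by MTT assay, with a stated time of 48 h; a lower number here means a stronger inhibitor, a higher number a weaker inhibitor
- compound 2, `COc1cc2ccc(=O)oc2cc1OCCCOc1no[n+]([O-])c1S(=O)(=O)c1ccccc1`: 2900 nM in this assay
- compound 3, `COc1cc2cc(NC(C)=O)c(=O)oc2cc1OCCCCOc1no[n+]([O-])c1S(=O)(=O)c1ccccc1`: 3290 nM in this assay

The three numbers sit close together. The gap from compound 1 to compound 3 and the gap from compound 1 to compound 2 are both within the scatter, so the three compounds cannot be told apart in this assay on the values shown; compound 1 stands at much the same level as the other two.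

Compound 4, `COc1cc2cc(N)c(=O)oc2cc1OCCOc1no[n+]([O-])c1S(=O)(=O)c1ccccc1`, differs from compound 1 in one place: amino in place of hydrogen on an aromatic carbon. Among the measured compounds shown here, no measured pair shows this change on its own. The nearest pointer is compound 3, which carries an acetamido group at that position of the core, with a longer linker, and gives 3290 nM, a number within the scatter of compound 1. On that basis the step from compound 1 to compound 4 is expected to be small, with no clear direction, and likely within the scatter.

The estimate for compound 4 in this assay is 3000 nM, with an expected range from 1200 nM to 7500 nM, meaning an expected step of a 1.2-fold lower number from compound 1 to compound 4 (0.08 log units; within the scatter).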

Compound 4, half-maximal inhibitory concentration: 3060 nM
The estimate for compound 4 lay 1.0-fold (0.01 log units) below the measured number; the measured number falls inside the stated range.
By their numbers in this assay, from the lowest: compounds 2, 4, 3 and 1 (each within the scatter of the next).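

In this assay, amino in place of hydrogen on an aromatic carbon, two atoms from the ring oxygen, gives a 1.2-fold lower number from compound 1 to compound 4 (0.07 log units; within the scatter). Among the compounds shown here, this is the first pair that differs in one place only, and it shows that this position can take an amino group with no change that can be told from the scatter, with the linker of compound 1 held constant. No measured evidence bears on the reason for this outcome.

From the compounds shown here alone, whether a different group at this place, such as a carboxylic acid, a hydroxyl or a longer alkyl chain, would shift the number beyond the scatter remains open. Also open, going by these compounds, is whether the amino step gives the same result on a longer linker, such as that of compound 2.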